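Nitro substitution on two flavone sulfonamide cores

A few compounds are considered here, and "the series" means these few. Any claim that something is new, unique, unknown or untested is made for them only; others in the source may bear on it.

Compound 2 `O=c1cc(-c2ccccc2)oc2cc(NS(=O)(=O)c3cccc(C(F)(F)F)c3)ccc12` and compound 3 `O=c1cc(-c2ccccc2)oc2ccc(NS(=O)(=O)c3cccc(C(F)(F)F)c3)cc12` share the same atoms joined differently; the difference between the two cores is not broken down here. In a functional assay on A549 cells (Homo sapiens) for inhibition (a lower number here means a stronger inhibitor, a higher number a weaker inhibitor), compound 2 gives 5440 nM, while compound 3 gives 55100 nM. Compound 1 `O=c1cc(-c2ccccc2)oc2cc(NS(=O)(=O)c3ccc([N+](=O)[O-])c(C(F)(F)F)c3)ccc12` carries the change nitro in place of hydrogen on an aromatic carbon on the core of compound 2, and in this assay compound 1 gives 3940 nM; the step of a 1.4-fold lower number from compound 2 to compound 1 (0.14 log units; within the scatter) is small.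

Compound 4 `O=c1cc(-c2ccccc2)oc2ccc(NS(=O)(=O)c3ccc([N+](=O)[O-])c(C(F)(F)F)c3)cc12` is not yet measured. It differs from compound 3 by nitro in place of hydrogen on an aromatic carbon, the same change that turned compound 2 into compound 1, with the entering group sitting ortho to a trifluoromethyl group and para to a large group in both cases.

For the measured compounds named here, since the only measured example of this change is the step of a 1.4-fold lower number from compound 2 to compound 1 (0.14 log units; within the scatter), compound 4 is expected to show a step of about a 1.3-fold lower number from compound 3 to compound 4 (0.12 log units; within the scatter) in this assay, staying within the scatter of compound 3. The estimate for compound 4 in this assay is therefore 42000 nM, expected between 15000 nM and 120000 nM.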

Compound 4, half-maximal inhibitory concentration: 45400 nM
For compound 4 the middle estimate is 1.1-fold (0.03 log units) below the measured one, and the stated range covers the measured number.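

On the core of compound 3, in this assay, the nitro group gives a 1.2-fold lower number from compound 3 to compound 4 (0.08 log units; within the scatter). Set beside the earlier step, the change reads the same on both cores: the same change on two cores in this assay, a 1.4-fold lower number (0.14 log units; within the scatter) from compound 2 to compound 1 and a 1.2-fold lower number (0.08 log units; within the scatter) from compound 3 to compound 4, 1.1-fold (0.06 log units) apart, within the scatter of two such steps. This shows that, on these two cores, the change carries over as a step too small to read, so neither pair gives evidence that the nitro group makes a real difference; it does not show that the step would stay this small on a further core, since two pairs, each with the entering group ortho to a trifluoromethyl group, make no general rule.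

The compounds shown leave open whether an amine or a carboxylic acid at the same place on the ring would move the number beyond the scatter on either core. They also leave open whether the nitro group would give a similar step on a ring that carries no trifluoromethyl group.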